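The source may report more compounds than this note shows. Statements on the series, on what has been measured and on what is new or still open speak of the compounds shown alone.

Compound 3 `Nc1ccccc1NC(=O)c1ccc(COc2ccc(Cl)cc2)cc1` carries a chloro group on the outer ring, and in a functional assay on A549 cells (Homo sapiens) for antiproliferative activity, read by CCK-8 assay, with a stated time of 72 h (a higher number here means a weaker inhibitor, a lower number a stronger inhibitor), compound 3 reaches only the limit of the assay, > 32000 nM, which is not a number. Its two close relatives give numbers: compound 1 `Nc1ccccc1NC(=O)c1ccc(COc2ccc(F)cc2)cc1`, with fluoro in that position, gives 5370 nM in this assay, and compound 2 `Cc1ccc(OCc2ccc(C(=O)Nc3ccccc3N)cc2)cc1`, with methyl there, gives 5430 nM. The step of an at least 5.9-fold higher number from compound 1 to compound 3 (0.77 log units; beyond the scatter) and the step of an at least 5.8-fold higher number from compound 2 to compound 3 (0.77 log units; beyond the scatter) thus both run toward the limit, while the step of a 1.0-fold higher number from compound 1 to compound 2 (0.00 log units; within the scatter) is flat. The limit is the one described by the limit of > 32000 nM in this assay, at which 1 of the 3 values shown sits.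

Compound 4 `Nc1ccccc1NC(=O)c1ccc(COc2ccc([N+](=O)[O-])cc2)cc1` is the next change on the same ring: nitro in place of chloro on an aromatic carbon. Within the data shown here, no measured step swaps chloro for nitro, so the two steps that end at compound 3 only show that this position is sensitive, in both directions from the limit. On that basis the number for compound 4 is expected to fall somewhere between the limit of compound 3 and the values of compound 1 and compound 2, with a real chance of another limit. The expected step is an at least 2.1-fold lower number from compound 3 to compound 4 (0.32 log units; beyond the scatter). The estimate for compound 4 in this assay is 15000 nM, expected to lie between 3000 nM and 60000 nM.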

Compound 4, half-maximal inhibitory concentration: > 32000 nM
Compound 4: a limit, no number (the forecaster's own chance of this, stated with the estimate: 40%); middle value at least 2.1-fold (0.32 log units) from the limit.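

In this assay compound 4 gives > 32000 nM, which is a limit of the assay and not a number. Nitro in place of fluoro gives an at least 5.9-fold higher number from compound 1 to compound 4 (0.77 log units; beyond the scatter), and nitro in place of methyl gives an at least 5.8-fold higher number from compound 2 to compound 4 (0.77 log units; beyond the scatter), so the move to the limit at this position is no longer a single case tied to chloro: a second, different group on the same aromatic carbon does the same. The step between the chloro and nitro compounds cannot be read, as both ends are limits, and the two groups can therefore not be ranked against each other, which leaves the series in this state: the limit of > 32000 nM in this assay, at which 2 of the 4 values shown sit.

As far as these compounds go, what remains open is how far past the limit compound 3 and compound 4 lie, and whether they differ at all. From the compounds shown here alone, it is also open what an amine, a carboxylic acid or a methoxy group on this carbon would do, and whether any such group would join fluoro and methyl in giving a number or would instead end at the limit too.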